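Extending the side chain on the chlorinated compound 3

This account rests on a few compounds, and the source may have more. Where it says the series, first, only, none or still open, it means among the compounds named here.

Values in a functional assay on A549 cells (Homo sapiens) for antiproliferative activity, read by MTT assay, with a stated time of 48 h; a lower number here means a stronger inhibitor, a higher number a weaker inhibitor:
- compound 1 `CN(C)CCn1c(N)c(-c2nc3ccccc3[nH]2)c2nc(C#N)c(C#N)nc21`: > 50000 nM (a limit)
- compound 2 `CN(C)CCCn1c(N)c(-c2nc3ccccc3s2)c2nc(C#N)c(C#N)nc21`: 8870 nM
- compound 3 `CN(C)CCn1c(N)c(-c2nc3cc(Cl)ccc3[nH]2)c2nc(C#N)c(C#N)nc21`: > 50000 nM (a limit)
- compound 4 `CCN(CC)CCCCn1c(N)c(-c2nc3cc(Cl)ccc3[nH]2)c2nc(C#N)c(C#N)nc21`: not yet measured

Compound 3 gives > 50000 nM in this assay, which is a limit of the assay and not a number. Compound 3 therefore sits at the limit of > 50000 nM in this assay, at which 2 of the 3 values shown sit. Compound 4 keeps the shared core and the chloro group but carries 2-(diethylamino)ethyl in place of dimethylamino on a saturated chain carbon, two bonds along the chain from an aromatic nitrogen.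

Within the data shown here, the one measured step in reach is a step that the two limits leave unreadable from compound 1 to compound 3. Among the measured compounds shown here, it concerns a different place on the molecule and offers no size to carry over, so no measured step bears directly on this change. For the measured compounds named here, the only other guide is compound 2, which gives 8870 nM and shows that a number can be reached, although it differs from compound 3 in more than one place. A move towards stronger inhibition is thus expected, though only tentatively, and a result at the limit remains quite possible. The expected change is an at least 2.5-fold lower number from compound 3 to compound 4 (0.39 log units; beyond the scatter). For compound 4 the estimate is 20000 nM, with an expected range of 5000 nM to 50000 nM.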

Compound 4, half-maximal inhibitory concentration: 2270 nM
Estimate against measurement, compound 4: 8.8-fold (0.95 log units) above; the measured number lies below the stated range.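

In this assay compound 3 gives > 50000 nM, which is a limit of the assay and not a number. Setting 2-(diethylamino)ethyl in place of dimethylamino on a saturated chain carbon, two bonds along the chain from an aromatic nitrogen, gives an at least 22-fold lower number from compound 3 to compound 4 (1.34 log units; beyond the scatter), so this position on the side chain can move the result strongly, which the earlier compounds could not show for the chlorinated compound. Compound 4 thereby gives the chlorinated series a readable number for the first time among the compounds shown, and the two compounds with the shorter dimethylamino side chain and this core stay at the limit: the limit of > 50000 nM in this assay, at which 2 of the 4 values shown sit.

The step joins a longer chain to ethyl groups on the amine in place of methyl groups, and the compounds shown do not tell whether a 4-(dimethylamino)butyl chain alone or the diethylamino group alone would carry the gain. They also leave open whether the chloro group contributes to the result of compound 4, and how a still longer chain or a cyclic amine such as piperidine would fare at this position.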